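Methoxy for Methyl: What Compound 4 Might Show

The source may report more compounds than this note shows. Statements on the series, on what has been measured and on what is new or still open speak of the compounds shown alone.

Measured so far in a functional assay on SGC-7901 cells (Homo sapiens) for antiproliferative activity, read by sulforhodamine B assay, with a stated time of 72 h; a lower number here means a stronger inhibitor, a higher number a weaker inhibitor:
compound 1, `FC(F)(F)c1ccccc1NC(=S)N/N=C/c1ccc2ccccc2n1`: 20700 nM
compound 2, `Cc1cccc(NC(=S)N/N=C/c2ccc3ccccc3n2)c1`: a limit, > 100000 nM
compound 3, `NC(=S)N/N=C/c1nc2ccccc2s1`: a limit, > 100000 nM

Compound 2 sits at the limit of > 100000 nM in this assay, at which 2 of the 3 values shown sit. Its result is a limit, not a number. Compound 3 likewise returns only a limit in this assay, > 100000 nM. Compound 1 is the only one of the three with a number; in this assay compound 1 gives 20700 nM. No step between any two of these compounds is established, so the values can only be set side by side: compound 1 has a number, compound 2 does not.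

Compound 4, `COc1cccc(NC(=S)N/N=C/c2ccc3ccccc3n2)c1`, differs from compound 2 in one place: methoxy in place of methyl on an aromatic carbon. The change is small in size and the shared core is untouched. With compound 2 already at a limit, the expected step of a number no higher from compound 2 to compound 4 (the limit leaves the size open) is none beyond the usual scatter, and the most probable outcome is that this assay again reports only a limit. Compound 4 is therefore estimated at 100000 nM, with a range from 30000 nM to 300000 nM.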

Compound 4, half-maximal inhibitory concentration: 79400 nM
Beside the measured number, compound 4's estimate is 1.3-fold (0.10 log units) above it; low and high end bracket the measured number.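

In this assay, the change from 3-methylphenyl to 3-methoxyphenyl yields a measured number, with compound 4 giving 79400 nM. Compound 2 has only a limit. Read as a step, this is an at least 1.2-fold lower number from compound 2 to compound 4 (0.10 log units; that floor lies within the scatter), so the printed floor alone does not establish that methoxy outperforms methyl here, even though compound 4 can be placed on the scale and compound 2 cannot. The true size of the step stays unknown because compound 2 has only a limit to set against it: the limit of > 100000 nM in this assay, at which 2 of the 4 values shown sit.

The compounds shown leave open how much further the number would move if this aromatic carbon carried a different group, such as a hydroxyl, an amine or an ethoxy, and whether any of these would return a number at all. Within the data shown here, they also leave open whether methoxy would give a comparable result at another place on that ring, since the only substituent change that can be read here is this single swap at this one position.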